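Sulfonamide piperidine series: cytotoxicity expectation for compound 3

A few compounds are considered here, and "the series" means these few. Any claim that something is new, unique, unknown or untested is made for them only; others in the source may bear on it.

Of the compounds shown here, two have been tested in an ADME assay on HCT-116 cells (Homo sapiens) for cytotoxicity, read by CellTiter-Glo, with a stated time of 72 h; a higher number here means a weaker inhibitor, a lower number a stronger inhibitor. Compound 1, `Cc1cc(C)c(S(=O)(=O)N2CCN(C3CN4CCC3CC4)CC2)c(C)c1`, returns only a limit in this assay, > 5000 nM. Compound 2, `CC1CCN(C2CCN(S(=O)(=O)c3cccc(-c4ccc(F)cc4)c3)CC2)CC1`, likewise returns only a limit in this assay, > 5000 nM. Going by the values given here, neither result is a number; both sit at the limit of > 5000 nM in this assay, at which 2 of the 2 values shown sit, so no step between measured compounds can be drawn, and compound 2 stands at the edge of what this assay reports, with no ordering against compound 1 possible.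

Compound 3, `CC1CCN(C2CCN(S(=O)(=O)c3cccc(Cl)c3)CC2)CC1`, is the next compound to be measured. It differs from compound 2 by chloro in place of 4-fluorophenyl on an aromatic carbon; the rest of the structure is unchanged.

With both values shown being limits, nothing measured anchors the size of this change. The step is expected to be none beyond the scatter, since compound 2 sits at its limit of > 5000 nM: a step that the limit leaves unreadable from compound 2 to compound 3. Compound 3 is therefore expected to land at 8000 nM, within a range from 3000 nM to 25000 nM, and most likely this assay will again report only a limit for compound 3.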

Compound 3, half-maximal inhibitory concentration: > 5000 nM
Compound 3 ended at the assay's limit; the forecaster's own chance of this, stated with the estimate: 85%; the middle value does not contradict the limit.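

No step can be read from compound 2 to compound 3, since both results in this assay are limits and not numbers: the limit of > 5000 nM in this assay, at which 3 of the 3 values shown sit.

The compounds shown leave open whether any member of the series gives a numerical value in this assay, and what chloro in place of 4-fluorophenyl does to that value.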